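A few compounds are considered here, and "the series" means these few. Any claim that something is new, unique, unknown or untested is made for them only; others in the source may bear on it.

Working notes on the series.

Two compounds have numbers in a functional assay on A549 cells (Homo sapiens) for antiproliferative activity, read by MTT assay; on this read-out lower numbers stand for stronger inhibition and higher numbers for weaker inhibition. Compound 1 `O=C(Nc1cccc(CNc2ncnc3ccccc23)c1)Nc1ccccc1F` carries the plain core with a fluoro-substituted phenylurea; in this assay compound 1 gives 26100 nM. Compound 2 `COc1cc2ncnc(NCc3cccc(NC(=O)Nc4ccc(C)cc4)c3)c2cc1OC` carries two methoxy groups on the core and a 4-methylphenyl urea; in this assay compound 2 gives 12900 nM. Compound 2 stands at the lower of the two numbers, and the gap to compound 1 lies beyond the scatter. For the measured compounds named here, no pair differing in a single place has been measured, so no single step in this assay has been quantified.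

Compound 3 `COc1cc2ncnc(NCc3cccc(NC(=O)Nc4ccc(F)cc4)c3)c2cc1OC` is the next entry. It differs from compound 2 by fluoro in place of methyl on an aromatic carbon, with the same difference one bond further out reading 4-methylphenyl to 4-fluorophenyl. Going by the values given here, with no comparable step in this assay to lean on, the expectation for compound 3 is a step from compound 2 that stays within the scatter, in no firm direction, estimated as a 1.1-fold lower number from compound 2 to compound 3 (0.03 log units; within the scatter). The estimate for compound 3 in this assay is therefore 12000 nM, with a range from 4000 nM to 36000 nM.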

Compound 3, half-maximal inhibitory concentration: 16900 nM
Compound 3: middle estimate off by 1.4-fold (0.15 log units), on the low side; the measured number falls inside the stated range.
By their numbers in this assay, from the lowest: compounds 2, 3 and 1 (each within the scatter of the next, the first and the last beyond it).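

For the compounds shown here, this is the first single-place step: in this assay, fluoro in place of methyl on an aromatic carbon, para to a large group, gives a 1.3-fold higher number from compound 2 to compound 3 (0.12 log units; within the scatter), and that step lies within the scatter. At this place on the urea's outer ring, 4-methylphenyl and 4-fluorophenyl therefore cannot be told apart in this read-out, so this exchange of one heavy atom, with no change in the hydrogen-bond donor or acceptor counts, has no resolved effect on the number. No measurement at hand bears on why the exchange leaves the number within the scatter.

Going by these compounds alone, whether a trifluoromethyl group, an amine or a carboxylic acid at this same place would move the number beyond the scatter remains open, since methyl and fluoro are the only groups compared here. Within the data shown here, the two methoxy groups on the shared core also have no single step of their own, and compound 1 differs from compound 2 and compound 3 in more than one place, so their contribution cannot be separated from that of the urea substituent.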